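The source may hold more compounds than are shown below. What is called first, only, known or untested is meant among the compounds shown, and "the series" means these compounds.

Measured so far:
compound 1 `O=C(CCCc1ccc(F)cn1)N1CCc2c(Cl)c(O)c(O)c(Cl)c2C1` — 25%
compound 2 `O=C(CCCc1ccc(C(F)(F)F)cn1)N1CCc2c(Cl)c(O)c(O)c(Cl)c2C1` — 19%

In a functional assay (Homo sapiens), tested at 10 uM (a higher number here means a weaker effect of the compound at the concentration tested, a lower number a stronger effect), compound 2 gives 19%, and compound 1 gives 25%; the two values fall within the scatter of each other. Among the measured compounds shown here, the one measured step, a number 6 percentage points lower from compound 1 to compound 2 (within the scatter), changes the same aromatic carbon that is changed here. Compound 3 `O=C(CCCc1ccc(Cl)cn1)N1CCc2c(Cl)c(O)c(O)c(Cl)c2C1` differs from compound 2 by chloro in place of trifluoromethyl on an aromatic carbon. For the measured compounds named here, since the only step at this position stayed within the scatter, no step beyond the scatter is expected in this assay for this change either. Compound 3 is therefore estimated at 22%, range 10% to 35%, the expected step being a number 3 percentage points higher from compound 2 to compound 3 (within the scatter).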

Compound 3, a percentage reported as activity, at one concentration (the size of the read-out at that concentration, not a potency): 15%
The estimate for compound 3 lay 7 percentage points above the measured number, and the stated range covers the measured number.
By their numbers in this assay, from the lowest: compounds 3, 2 and 1 (each within the scatter of the next).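

In this assay, chloro in place of trifluoromethyl (a number 4 percentage points lower from compound 2 to compound 3 (within the scatter)) swaps a group of 4 heavy atoms for a single atom, and chloro in place of fluoro gives the second step (a number 10 percentage points lower from compound 1 to compound 3 (within the scatter)). Fluoro, trifluoromethyl and chloro on this aromatic carbon, two atoms from the ring nitrogen, thus all lie within the scatter of one another. No measurement here offers an explanation for these numbers. As far as these compounds go, whether an amine or a carboxylic acid on this carbon would give a step beyond the scatter remains open, as does the result of a longer chain on the amide carbonyl.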